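The source may hold more compounds than are shown below. What is called first, only, known or untested is meant among the compounds shown, and "the series" means these compounds.

Three measured compounds share one core: compound 1 `Cc1nc(N2CCC(N3C(=O)CCC3=O)CC2)nc2ccc(NC(=O)/C=C/c3ccc(OC(F)(F)F)cc3)cc12`, compound 2 `Cc1nc(NCCCNS(C)(=O)=O)nc2ccc(NC(=O)/C=C/c3ccc(OC(F)(F)F)cc3)cc12` and compound 3 `COc1ccc(/C=C/C(=O)Nc2ccc3nc(N4CCC(O)(C5CC5)CC4)nc(C)c3c2)cc1`. In an assay on CHO-K1 cells for displacement of a labelled ligand from melanin-concentrating hormone receptor 1 (Homo sapiens), read by scintillation proximity assay, with a stated time of 2 h (on this read-out higher numbers stand for weaker inhibition and lower numbers for stronger inhibition), compound 1 gives 94 nM. Compound 2 gives 54 nM in this assay, and compound 3 gives 116 nM in this assay. Compound 1 thus holds the second highest of the three numbers; compound 3 is its nearest neighbour and compound 2 the furthest from it, yet both gaps fall within the usual scatter, so no order among the three can be read from these values.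

Compound 4 `Cc1nc(N2CCC(N3CCCS3(=O)=O)CC2)nc2ccc(NC(=O)/C=C/c3ccc(OC(F)(F)F)cc3)cc12` is not yet measured. Relative to compound 1 it carries a group of 7 heavy atoms (3 carbon, 1 nitrogen, 2 oxygen, 1 sulfur; one five-membered non-aromatic ring with 2 hetero atoms) in place of a group of 7 heavy atoms (4 carbon, 1 nitrogen, 2 oxygen; one five-membered non-aromatic ring with 1 hetero atom), on a saturated ring carbon. The group that leaves and the group that enters match in heavy-atom count, in hydrogen-bond acceptors, in having no donors and no net charge; what differs is a five-membered non-aromatic ring with two hetero atoms in place of one with one hetero atom, on the same saturated ring carbon. Within the data shown here, no step between two measured compounds in this set tests such a swap, so there is no measured precedent. The expectation is a step of a 1.0-fold lower number from compound 1 to compound 4 (0.02 log units; within the scatter) that stays within the scatter, in no clear direction. Compound 4 is expected to give about 90 nM in this assay, with a range from 40 nM to 200 nM.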

Compound 4, half-maximal inhibitory concentration: 4 nM
The estimate for compound 4 lay 23-fold (1.35 log units) above the measured number; measured number below the stated range.
By their numbers in this assay, from the lowest: compound 4; then compounds 2, 1 and 3 (each within the scatter of the next, the first and the last beyond it).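

Among these compounds, at this position, on a saturated ring carbon of the six-membered non-aromatic ring with 1 nitrogen, exchanging 2,5-dioxopyrrolidin-1-yl for the five-membered non-aromatic ring with 2 hetero atoms gives, in this assay, a 24-fold lower number from compound 1 to compound 4 (1.37 log units; beyond the scatter), the first step that can be read beyond the scatter. Entering and leaving groups match in heavy-atom count, in hydrogen-bond donors and acceptors and in having no net charge, so the number responds strongly to a change that these counts do not register, something the three earlier compounds, which offered no step at all, could not show. Nothing at hand accounts for the size of this step.

This single pair does not separate the role of the ring sulfur from that of the ring itself, and an open-chain methanesulfonamide, a six-membered cyclic sulfonamide or a simple amine on the same saturated ring carbon would address that. Going by these compounds, whether the step carries over to a compound with the methoxy group of compound 3 in place of trifluoromethoxy also stays open.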